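A few compounds are considered here, and "the series" means these few. Any claim that something is new, unique, unknown or untested is made for them only; others in the source may bear on it.

Measured so far in a functional assay, with a stated time of 30 min; a lower number here means a stronger inhibitor, a higher number a weaker inhibitor:
- compound 1, `COc1ccc(C2CC(=NOC(=O)c3ccc(F)cc3)CC(c3ccc(OC)cc3)N2C)cc1`, gives 152000 nM
- compound 2, `COc1ccc(C2CC(=NOC(=O)c3ccc(Cl)cc3)CC(c3ccc(OC)cc3)N2C)cc1`, gives 135000 nM
- compound 3, `COc1ccc(C2CC(=NOC(=O)c3ccccc3O)CC(c3ccc(OC)cc3)N2C)cc1`, gives 29000 nM

Compound 2 holds the second highest of the three numbers. Its nearest neighbour is compound 1, the step of a 1.1-fold lower number from compound 1 to compound 2 (0.05 log units; within the scatter) lying within the scatter; its furthest is compound 3, by the step of a 4.7-fold lower number from compound 2 to compound 3 (0.67 log units; beyond the scatter).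

Compound 4, `COc1ccc(C2CC(=NOC(=O)c3ccc(O)cc3)CC(c3ccc(OC)cc3)N2C)cc1`, is not yet measured. It differs from compound 2 by hydroxy in place of chloro on an aromatic carbon.

Among the compounds with values here, two measured steps bear on this change. The halogen swap a 1.1-fold lower number from compound 1 to compound 2 (0.05 log units; within the scatter) shows that exchanging one small group for another at that carbon can leave this assay unmoved. The entry of a hydroxyphenyl, in a 4.7-fold lower number from compound 2 to compound 3 (0.67 log units; beyond the scatter) and a 5.2-fold lower number from compound 1 to compound 3 (0.72 log units; beyond the scatter), gave modest steps towards lower numbers, though there the group enters as 2-hydroxyphenyl, whereas in compound 4 it is 4-hydroxyphenyl. Within the data shown here, no measured pair carries a hydroxy at this carbon, so the expectation is loose.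

A modest step towards a lower number, a 2.7-fold lower number from compound 2 to compound 4 (0.43 log units; beyond the scatter), is expected from this change. Compound 4 is estimated at 50000 nM, with a range from 15000 nM to 160000 nM.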

Compound 4, half-maximal inhibitory concentration: 25000 nM
Compound 4: middle estimate off by 2.0-fold (0.30 log units), on the high side; measured number inside the range.
By their numbers in this assay, from the lowest: compounds 4 and 3 (each within the scatter of the next); then compounds 2 and 1 (each within the scatter of the next).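

In this assay, the step of a 5.4-fold lower number from compound 2 to compound 4 (0.73 log units; beyond the scatter) shows that this carbon does respond to the group it carries, and a 6.1-fold lower number from compound 1 to compound 4 (0.78 log units; beyond the scatter) gives the same picture starting from fluoro, whereas the exchange of one halogen for the other had left the number unmoved. The step of a 1.2-fold lower number from compound 3 to compound 4 (0.06 log units; within the scatter) shows that 4-hydroxyphenyl and 2-hydroxyphenyl read alike, so among these four compounds, both hydroxy compounds sit apart from both halogen compounds, with no compound going against this. Nothing measured here accounts for the difference between hydroxy and the halogens.

The compounds shown leave open how a methoxy or an amine at this carbon would read in this assay. Also open, on these data alone, is whether a carboxylic acid there would sit with the hydroxy compounds or with the halogen compounds.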